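A few compounds are considered here, and "the series" means these few. Any claim that something is new, unique, unknown or untested is made for them only; others in the source may bear on it.

Measured so far in a physicochemical assay for lipophilicity, using the shake flask method, in phosphate buffer, measured as octanol-water partition, with a stated time of 24 h, at pH 7.4, tested at 100 uM; on this read-out higher numbers stand for higher lipophilicity and lower numbers for lower lipophilicity:
- compound 1 `CCOc1cc(C)c(-c2cccc(COc3ccc(OCC(=O)O)c(F)c3)c2)c(C)c1` stands at 3.48
- compound 2 `Cc1cc(OCC(=O)N2CCOCC2)cc(C)c1-c1cccc(COc2ccc(OCC(=O)O)c(F)c2)c1` stands as "not determined" (no result reported)

Compound 2 therefore has no number on this scale and offers no measured starting point. The next compound is compound 3 `Cc1cc(OCCCO)cc(C)c1-c1cccc(COc2ccc(OCC(=O)O)c(F)c2)c1` and the change is 2-hydroxyethyl in place of (morpholin-4-yl)carbonyl on a saturated chain carbon bound to an oxygen on an aromatic ring (3-hydroxypropoxy takes the place of ((morpholin-4-yl)carbonyl)methoxy). In this assay a small upward step from compound 2 to compound 3 is expected, hardly beyond the scatter, though without a number for compound 2 this cannot be checked. For the measured compounds named here, the only anchor is compound 1 at 3.48 and compound 3 is expected to lie under it. For compound 3 the expected value is 2.6 with a range from 2.1 to 3.1 as estimated here.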

Compound 3, distribution coefficient: 2.73
Compound 3: middle estimate off by 0.13 log units, on the low side; the measured number falls inside the stated range.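

In this assay, hydroxymethyl in place of hydrogen on a saturated chain carbon, two bonds along the chain from an oxygen on an aromatic ring, gives a number 0.75 log units lower from compound 1 to compound 3 (beyond the scatter), so this position responds to a small change at the chain end. The step from compound 2 cannot be read, which leaves (morpholin-4-yl)carbonyl unplaced on this scale. No evidence bearing on the cause of the step is at hand. Still open, going by these compounds, is where an amine or a carboxylic acid at the end of this chain would lie. On these data alone, a longer chain carrying the same terminal hydroxyl also remains open.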